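The compounds below may be only part of what the source reports. "The series", "measured", "known", "first", "only" and "open" are said of these compounds alone.

Cytotoxicity in an ADME assay on MT4 cells (Homo sapiens) for cytotoxicity, read by MTT assay, with a stated time of 5 days (on this read-out higher numbers stand for lower toxicity in this test and lower numbers for higher toxicity in this test), measured compounds:

Compound 1, `COC(=O)Cn1cc(CNC(=O)c2cnc(Nc3ccc(C#N)cc3)cc2Oc2c(C)cc(C)cc2C)nn1`: 13800 nM
Compound 2, `Cc1cc(C)c(Oc2cc(Nc3ccc(C#N)cc3)ncc2C(=O)NCc2cn(Cc3ccc(Cl)cc3)nn2)c(C)c1`: >= 120000 nM, a limit of the assay, not a number
Compound 3, `Cc1cc(C)c(Oc2cc(Nc3ccc(C#N)cc3)ncc2C(=O)NCc2cn(CCCO)nn2)c(C)c1`: 25200 nM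

Compound 3 holds the highest of the two numbers given in this assay; its nearest neighbour is compound 1, and the gap a 1.8-fold higher number from compound 1 to compound 3 (0.26 log units; within the scatter) is within the scatter. Compound 2 sits at the limit (the limit of >= 120000 nM in this assay, at which 1 of the 3 values shown sits), so the step of an at least 4.7-fold lower number from compound 2 to compound 3 (0.67 log units; beyond the scatter) is known only as a bound.

The unmeasured compound 4, `Cc1cc(C)c(Oc2cc(Nc3ccc(C#N)cc3)ncc2C(=O)NCc2cn(CC(=O)N3CCCC3)nn2)c(C)c1`, differs from compound 3 at the group on the saturated chain carbon bound to the aromatic nitrogen: (pyrrolidin-1-yl)carbonyl in place of 2-hydroxyethyl on a saturated chain carbon bound to an aromatic nitrogen.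

Going by the values given here, two measured steps touch this position. The exchange of methoxycarbonyl for 2-hydroxyethyl, a 1.8-fold higher number from compound 1 to compound 3 (0.26 log units; within the scatter), stays within the scatter; the exchange of 4-chlorophenyl for 2-hydroxyethyl, an at least 4.7-fold lower number from compound 2 to compound 3 (0.67 log units; beyond the scatter), is at least modest. The (pyrrolidin-1-yl)carbonyl entering in compound 4 carries a carbonyl and no ring aromatic, so the closer comparison is the step from compound 1, which is flat. No step beyond the scatter is therefore expected from compound 3 to compound 4 in this assay, with only a modest chance that the number reaches the limit.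

Compound 4 is expected to give about 20000 nM in this assay, within 8000 nM to 60000 nM; the expected step is a 1.3-fold lower number from compound 3 to compound 4 (0.10 log units; within the scatter).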

Compound 4, half-maximal cytotoxic concentration: 58100 nM
The estimate for compound 4 lay 2.9-fold (0.46 log units) below the measured number; the measured number falls inside the stated range.
By their numbers in this assay, from the lowest: compounds 1 and 3 (each within the scatter of the next); then compound 4. At a limit, above all of these: compound 2.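

In this assay the place on a saturated chain carbon bound to an aromatic nitrogen responds to more than the flat exchange of methoxycarbonyl for 2-hydroxyethyl indicated, and a step beyond the scatter does not need an aromatic ring to enter: (pyrrolidin-1-yl)carbonyl in place of 2-hydroxyethyl gives a 2.3-fold higher number from compound 3 to compound 4 (0.36 log units; beyond the scatter) in this series. Carrying a carbonyl is also not enough to place a group with the ester, since pyrrolidin-1-yl in place of methoxy on a carbonyl carbon gives a 4.2-fold higher number from compound 1 to compound 4 (0.62 log units; beyond the scatter) on the same shared core. Compound 2 remains a limit and not a number, so the exchange of 4-chlorophenyl for (pyrrolidin-1-yl)carbonyl, an at least 2.0-fold lower number from compound 2 to compound 4 (0.31 log units; beyond the scatter), is known only as a bound: the limit of >= 120000 nM in this assay, at which 1 of the 4 values shown sits.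

The compounds shown leave open whether the higher number of compound 4 goes with the amide carbonyl or with the five-membered ring, a separation that an open-chain diethylaminocarbonyl on the same carbon could make. Also open, going by these compounds, is how a carboxylic acid or a morpholin-4-ylcarbonyl group would read at this place in this test.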